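Chloro in Place of Fluoro on a Second Core

The compounds below may be only part of what the source reports. "The series", "measured", "known", "first", "only" and "open" are said of these compounds alone.

Compound 1 `CN(C)CCNc1nc(-c2ccc(NC(=O)Nc3ccc(F)cc3)cc2)nc2ccsc12` and compound 2 `CN(C)CCNc1nc(-c2ccc(NC(=O)Nc3ccc(Cl)cc3)cc2)nc2ccsc12` share one core and differ at a single point: chloro in place of fluoro on an aromatic carbon. In a functional assay on HT-29 cells (Homo sapiens) for cytotoxicity, read by MTT assay, with a stated time of 72 h (on this read-out higher numbers stand for weaker inhibition and lower numbers for stronger inhibition), compound 1 gives 350 nM, while compound 2 gives 95 nM, so the swap brought a 3.7-fold lower number from compound 1 to compound 2 (0.57 log units; beyond the scatter). Compound 3 `CCN(CC)CCCNc1nc(-c2ccc(NC(=O)Nc3ccc(F)cc3)cc2)nc2c(Cl)c(Cl)sc12` is built on a different core with a different amine chain; how its core differs from that of compound 1 is not broken down here. In this assay compound 3 gives 350 nM, level with compound 1 at the digits recorded.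

Compound 4 `CCN(CC)CCCNc1nc(-c2ccc(NC(=O)Nc3ccc(Cl)cc3)cc2)nc2c(Cl)c(Cl)sc12` stands to compound 3 exactly as compound 2 stands to compound 1: chloro in place of fluoro on an aromatic carbon. The surroundings of the change read the same in both pairs, on an aromatic carbon of a six-membered aromatic ring of carbon only, para to a large group, so this is the same change rather than merely a related one. Among the four compounds it occurs twice, and only once with a measured outcome.

In this assay the expected step of a 3.5-fold lower number from compound 3 to compound 4 (0.54 log units; beyond the scatter) rests on that single precedent, because the same swap gave a 3.7-fold lower number from compound 1 to compound 2 (0.57 log units; beyond the scatter). One example on a different core is a thin basis, so the range is kept wide. Compound 4 is therefore estimated at 100 nM, with a likely range from 45 nM to 230 nM.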

Compound 4, half-maximal inhibitory concentration: 250 nM
The estimate for compound 4 lay 2.5-fold (0.40 log units) below the measured number; measured number above the stated range.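

On the core of compound 3, in this assay, chloro in place of fluoro gave a 1.4-fold lower number from compound 3 to compound 4 (0.15 log units; within the scatter), so on this core the two compounds cannot be told apart. Among the compounds shown here, the step on the core of compound 1 lay beyond the scatter and this one lies within it, yet the gap between the two steps is small enough that they cannot be called different: the same change on two cores in this assay, a 3.7-fold lower number (0.57 log units; beyond the scatter) from compound 1 to compound 2 and a 1.4-fold lower number (0.15 log units; within the scatter) from compound 3 to compound 4, 2.6-fold (0.42 log units) apart, within the scatter of two such steps This shows that the change can be carried to the second core without a clear departure from the first result, but it does not show that the gain seen on the first core carries over, nor that it is lost, since only two pairs are available and the pairs differ in both core and amine chain, which leaves the influence of each unseparated.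

The compounds shown leave open whether the step would read the same with the amine chain of compound 1 on the core of compound 3, or with the amine chain of compound 3 on the core of compound 1. They also leave open how a bromo, methyl or methoxy group would behave on the same aromatic carbon, para to a large group, on either core.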